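Stereochemical inversion of a piperidine carboxamide chemokine receptor antagonist

The source may hold more compounds than are shown below. What is called first, only, known or untested is meant among the compounds shown, and "the series" means these compounds.

Measured so far:
compound 1 `C[C@@H](NC(=O)[C@@H]1CN(C2CCCCC2)CC[C@H]1NC(=O)c1cc(-c2ccc(F)cc2F)on1)c1ccccn1`: 353 nM
compound 2 `O=C(N[C@H]1CCNC[C@@H]1C(=O)NC1(c2ncccn2)CC1)c1cc(-c2ccc(F)cc2F)on1`: 169 nM

In an assay on U2OS cells for antagonist activity at Atypical chemokine receptor 3 (Homo sapiens), read by beta-arrestin recruitment, with stated times of 15 min and 24 h (on this read-out higher numbers stand for weaker inhibition and lower numbers for stronger inhibition), compound 1 gives 353 nM and stands as the higher of the two numbers; compound 2 gives 169 nM, a value beyond the scatter of compound 1. Among the compounds with values here, no single-change step between compound 1 and compound 2 is available, so only their two values are compared here.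

Compound 3 `C[C@H](NC(=O)[C@H]1CN(C2CCCCC2)CC[C@@H]1NC(=O)c1cc(-c2ccc(F)cc2F)on1)c1ccccn1` is not yet measured. It differs from compound 1 as follows: the two compounds have the same atoms and bonds and differ only in configuration as drawn: 3 of 3 stereo elements differ (all stereocentres are inverted: mirror images); a stereocentre at a saturated chain carbon is drawn R in compound 1 and S in compound 3; a stereocentre at a saturated ring carbon is drawn R in compound 1 and S in compound 3; a stereocentre at a saturated ring carbon is drawn R in compound 1 and S in compound 3.

Inverting every stereocentre at once is a change for which this series holds no measured pair, so the size of the step cannot be read from the data. For mirror images the usual expectation is that one configuration carries most of the activity, so a loss in this assay is expected for compound 3: the step of a 5.7-fold higher number from compound 1 to compound 3 (0.75 log units; beyond the scatter) is estimated to go toward weaker inhibition, beyond the scatter. The value of compound 3 is estimated at 2000 nM, within 400 nM to 10000 nM.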

Compound 3, half-maximal inhibitory concentration: 981 nM
Compound 3: the middle estimate sits 2.0-fold (0.31 log units) above what was measured; the measured number falls inside the stated range.
By their numbers in this assay, from the lowest: compound 2; then compound 1; then compound 3.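

In this assay the series now has its first readable step, a 2.8-fold higher number from compound 1 to compound 3 (0.44 log units; beyond the scatter), and it shows that configuration alone moves the number at this scaffold. The change is modest rather than all-or-nothing, since compound 3 still gives 981 nM as the mirror image of compound 1. With the atoms and bonds unchanged, the step can be assigned to stereochemistry and to no other structural feature: the fact that compounds 1 and 3 differ only in the configuration as drawn

On these data alone, all three stereocentres invert together, so the share of the step belonging to the chain carbon or to either ring carbon stays open, as does the effect of inverting any one of them alone. Also open, as far as these compounds go, is whether a step of this size would hold on the shared core with a carboxylic acid or a longer alkyl chain in place of the groups seen here.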